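The source may hold more compounds than are shown below. What is called first, only, known or untested is meant among the compounds shown, and "the series" means these compounds.

Of the compounds shown here, three sharing one core have been read in an ADME assay on microsomes from liver (Rattus norvegicus) for metabolic stability, with a stated time of 60 min, tested at 1 uM (on this read-out lower numbers stand for a less stable compound and higher numbers for a more stable compound), so far. Compound 3 (`COc1cnc2c(-c3ccnc(OC)c3)cnn2c1`) bears only hydrogen at the site of interest and gives 10% as the lowest of the three numbers. Compound 2 (`COc1cc(-c2cnn3cc(OC)c(C4CCOC4)nc23)ccn1`) gives 34% and compound 1 (`COc1cc(-c2cnn3cc(OC)c(C(C)(C)O)nc23)ccn1`) gives 92% on the same scale. Compound 4 (`COc1cc(-c2cnn3cc(OC)c(N(C)C)nc23)ccn1`) has dimethylamino in place of hydrogen on an aromatic carbon. The measured steps at this place all involve other groups. The step with oxolan-3-yl is modest (a number 24 percentage points lower from compound 2 to compound 3 (beyond the scatter)) and the step with 1-hydroxy-1-methylethyl is large (a number 82 percentage points lower from compound 1 to compound 3 (beyond the scatter)). These two groups also stand far apart from each other (a number 58 percentage points lower from compound 1 to compound 2 (beyond the scatter)). Neither group is dimethylamino, so these steps suggest a direction more firmly than a size. Among the measured compounds shown here, a modest rise is therefore expected, nearer the step involving compound 2 than the one involving compound 1. The expected change is a number 25 percentage points higher from compound 3 to compound 4 (beyond the scatter) in this assay terms. For compound 4 the estimate is 35% with an expected range from 15% to 60% on this read-out.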

Compound 4, percent of the compound remaining: 3%
Beside the measured number, compound 4's estimate is 32 percentage points above it; measured number outside the range, below it.
By their numbers in this assay, from the lowest: compounds 4 and 3 (each within the scatter of the next); then compound 2; then compound 1.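

In this assay, dimethylamino on this aromatic carbon cannot be told apart from hydrogen (a number 7 percentage points lower from compound 3 to compound 4 (within the scatter)), so replacing hydrogen at this place does not by itself give a higher number. It also falls clearly short of the two groups that stood above hydrogen, with a number 31 percentage points lower from compound 2 to compound 4 (beyond the scatter) and a number 89 percentage points lower from compound 1 to compound 4 (beyond the scatter), which shows that among these four compounds the read-out depends on which group enters, not merely on the place being filled. Nothing available here bears on the reason for this result.

The compounds leave open whether another amine, such as pyrrolidin-1-yl or morpholin-4-yl, would read like dimethylamino. They also leave open whether a plain 1-methylethyl group, without the hydroxy, would come near compound 1 or fall towards compound 3.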